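Methyl to Fluoro on the Aryl Ring of Compound 2

The source may hold more compounds than are shown below. What is called first, only, known or untested is meant among the compounds shown, and "the series" means these compounds.

Three compounds share a core in which a substituted pyridine carries a second six-membered ring bearing a (2-amino-2,4-dimethylpentyl)oxy group. Compound 1 `CC(=O)Nc1cc(-c2ccc(OC[C@@](C)(N)CC(C)C)c(F)c2)ccn1` carries an acetamide on the pyridine; in an assay on isolated protein for inhibition of AP2-associated protein kinase 1 (Homo sapiens), with a stated time of 3 h, in the presence of a further agent that is not named here (on this read-out higher numbers stand for weaker inhibition and lower numbers for stronger inhibition), compound 1 gives 0.8 nM. Compound 2 `COC(=O)Nc1cc(-c2ccc(OC[C@@](C)(N)CC(C)C)c(C)c2)ccn1` carries a methyl carbamate instead, and in this assay compound 2 gives 0.8 nM, the same number as compound 1 at the digits reported. Compound 3 `COC(=O)Nc1cc(-c2cnc(OC[C@@](C)(N)CC(C)C)c(Cl)c2)ccn1` has the ether on a pyridine with a chloro substituent; in this assay compound 3 gives 0.4 nM, a value that lies within the usual scatter of compound 2's result, so no real difference between them can be claimed.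

Compound 4 `COC(=O)Nc1cc(-c2ccc(OC[C@@](C)(N)CC(C)C)c(F)c2)ccn1` has not been measured. It differs from compound 2 in one place: fluoro in place of methyl on an aromatic carbon. Compound 1 already shows a fluoro at this position together with a value indistinguishable from compound 2, and compound 3 shows a different halogen with a value within the scatter. Nothing in these three results points to a shift beyond the scatter, so the expected step from compound 2 to compound 4 is essentially flat, a 1.1-fold lower number from compound 2 to compound 4 (0.06 log units; within the scatter). Compound 4 is therefore expected to give about 0.7 nM in this assay, with a plausible range from 0.3 nM to 1.6 nM.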

Compound 4, half-maximal inhibitory concentration: 1.1 nM
Beside the measured number, compound 4's estimate is 1.6-fold (0.20 log units) below it, and the stated range covers the measured number.
By their numbers in this assay, from the lowest: compounds 3, 1, 2 and 4 (each within the scatter of the next, the first and the last beyond it).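

In this assay, fluoro in place of methyl on this aromatic carbon, ortho to the (2-amino-2,4-dimethylpentyl)oxy group, gives a 1.4-fold higher number from compound 2 to compound 4 (0.14 log units; within the scatter), so with the methyl carbamate held constant this assay cannot tell the two groups apart at this position. Compound 1 and compound 2 differ in two places, so their shared value could say nothing about either change alone; the new compound separates the two changes, and methoxy in place of methyl on a carbonyl carbon gives a 1.4-fold higher number from compound 1 to compound 4 (0.14 log units; within the scatter), which means that this change, too, stays inside the normal noise of the measurement. No independent measurement is available here to explain why either change leaves the result within the scatter.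

Going by these compounds, whether a plain hydrogen, a nitrile or a trifluoromethyl on this aromatic carbon would also stay within the scatter remains open, as does the effect of an amine or a longer chain in place of the methoxy on the carbonyl carbon. Compound 3 differs from compound 4 in more than one place, so its chloro group cannot be compared directly with fluoro or methyl.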